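Chloro to methyl on the aryl ring of compound 1

A few compounds are considered here, and "the series" means these few. Any claim that something is new, unique, unknown or untested is made for them only; others in the source may bear on it.

Compound 1 `Cn1c(=O)c2nc(-c3ccc(Cl)cc3)[nH]c2n(C)c1=O` is the reference of this set: in an assay on membranes from brain for binding affinity to adenosine receptor A1 (Rattus norvegicus), read by radioligand binding (a lower number here means a stronger inhibitor, a higher number a weaker inhibitor), compound 1 gives 0.8 nM. Two compounds on a different core are also measured. Compound 2 `Cc1nn(C)c2c(O)nc(-c3ccc(Cl)cc3)nc12` gives 410 nM in this assay, and compound 3 `Cc1ccc(-c2nc(O)c3c(n2)c(C)nn3C)cc1` gives 400 nM. Compound 3 differs from compound 2 only by methyl in place of chloro on an aromatic carbon, and that change produced a 1.0-fold lower number from compound 2 to compound 3 (0.01 log units; within the scatter). How the core of compound 1 differs from that of compound 2 is not broken down here; the values alone show compound 1 far stronger than either.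

Compound 4 `Cc1ccc(-c2nc3c(=O)n(C)c(=O)n(C)c3[nH]2)cc1` carries the same change on the core of compound 1: methyl in place of chloro on an aromatic carbon. The surroundings of the change read identically for both pairs, so it is the same change, made twice in all among the compounds shown.

The expected step is a 1.1-fold higher number from compound 1 to compound 4 (0.05 log units; within the scatter), set beside a 1.0-fold lower number from compound 2 to compound 3 (0.01 log units; within the scatter); this rests on that one measured pair alone, with the caveat that it was observed on a different core. Compound 4 is therefore estimated at 0.9 nM in this assay, expected to lie between 0.3 nM and 3 nM.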

Compound 4, half-maximal inhibitory concentration: 0.8 nM
The estimate for compound 4 lay 1.1-fold (0.05 log units) above the measured number; the range from low to high includes it.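

Methyl in place of chloro on the aromatic carbon gives no change at the digits printed from compound 1 to compound 4 (within the scatter) in this assay, so on the core of compound 1 the swap leaves the number unmoved, as it does on the core of compound 2. The step therefore carries across these two cores with no difference that can be read: the same change on two cores in this assay, a 1.0-fold lower number (0.01 log units; within the scatter) from compound 2 to compound 3 and no change at the digits printed (within the scatter) from compound 1 to compound 4, 1.0-fold (0.01 log units) apart, within the scatter of two such steps
Going by these compounds alone, this shows only that one swap at one place is silent on two cores, each resting on a single pair; it does not show that a change with a real effect would carry over in the same way, or that a third core would behave alike.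

The compounds shown leave open whether a different group at this place, such as an amine, a carboxylic acid or a longer chain, would shift the number and whether it would do so equally on both cores. They also leave open which part of the core of compound 1 separates it from compound 2, since these two differ in more than one place.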